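Amide nitrogen substituent: 4-chlorophenyl replaced by isopropyl

A few compounds are considered here, and "the series" means these few. Any claim that something is new, unique, unknown or untested is made for them only; others in the source may bear on it.

Of the compounds shown here, three sharing one core have been measured in a functional assay on A549 cells (Homo sapiens) for antiproliferative activity, read by CCK-8 assay, with a stated time of 48 h; on this read-out lower numbers stand for stronger inhibition and higher numbers for weaker inhibition. Compound 1 `O=C(Nc1ccccc1)c1cc(Oc2ccc(/C=C/c3ccncc3)cc2)ccn1` gives 79700 nM, compound 2 `COc1ccc(NC(=O)c2cc(Oc3ccc(/C=C/c4ccncc4)cc3)ccn2)cc1` gives 25600 nM, and compound 3 `O=C(Nc1ccc(Cl)cc1)c1cc(Oc2ccc(/C=C/c3ccncc3)cc2)ccn1` gives 62100 nM. Compound 3 holds the second highest of the three numbers; its nearest neighbour is compound 1, within the scatter, and its furthest is compound 2, beyond the scatter. The measured steps are a 3.1-fold lower number from compound 1 to compound 2 (0.49 log units; beyond the scatter), a 1.3-fold lower number from compound 1 to compound 3 (0.11 log units; within the scatter) and a 2.4-fold higher number from compound 2 to compound 3 (0.38 log units; beyond the scatter), each a change on an aromatic carbon of the group attached to the amide nitrogen.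

Compound 4 `CC(C)NC(=O)c1cc(Oc2ccc(/C=C/c3ccncc3)cc2)ccn1` differs from compound 3 in that (isopropyl in place of 4-chlorophenyl on an amide-type nitrogen). Among the compounds with values here, no measured step removes the ring from the amide nitrogen altogether, so the three steps bear on this change only loosely; they show that changes at this end of the molecule have moved the number by modest amounts at most. A change of similar, modest size is therefore expected, with no firm direction, so that a 1.1-fold higher number from compound 3 to compound 4 (0.05 log units; within the scatter) is the expected step. Compound 4 is estimated at 70000 nM, with a range of 25000 nM to 200000 nM.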

Compound 4, half-maximal inhibitory concentration: 20600 nM
The estimate for compound 4 lay 3.4-fold (0.53 log units) above the measured number; the whole stated range lies above it.
By their numbers in this assay, from the lowest: compounds 4 and 2 (each within the scatter of the next); then compounds 3 and 1 (each within the scatter of the next).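

Losing the aromatic ring from the amide nitrogen costs no activity in this assay: isopropyl gives a 3.0-fold lower number from compound 3 to compound 4 (0.48 log units; beyond the scatter) and a 3.9-fold lower number from compound 1 to compound 4 (0.59 log units; beyond the scatter), so a small alkyl group is tolerated at this position. Compound 2 goes against any general advantage of isopropyl over an aromatic ring, with a 1.2-fold lower number from compound 2 to compound 4 (0.09 log units; within the scatter), so isopropyl and 4-methoxyphenyl cannot be told apart here. Nothing available explains why the number moves at this position.

Still open, from the compounds shown here alone, is whether a longer chain such as n-butyl, a saturated ring such as cyclohexyl, or a chain ending in an amine or a carboxylic acid would lower the number further than isopropyl. Also open, going by these compounds, is whether a methyl or an unsubstituted amide would hold the number of compound 4.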